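From 3-fluorophenyl to 4-fluorophenyl on a sulfur

This account rests on a few compounds, and the source may have more. Where it says the series, first, only, none or still open, it means among the compounds named here.

In a functional assay on A-375 cells (Homo sapiens) for inhibition, read by CCK-8 assay, with a stated time of 72 h, tested at 2 uM (a lower number here means less inhibition of growth, a higher number more inhibition of growth at the concentration tested), compound 1 `Nc1ccccc1NC(=O)/C=C/c1ccc(CSc2cccc(F)c2)cc1` gives 6.75%. That sits within the scatter of compound 2 `COc1ccc(SCc2ccc(C(=O)Nc3ccccc3N)cc2)cc1` at 10.2% and well short of compound 3 `Nc1ccccc1NC(=O)c1ccc(CSc2cccc(F)c2)cc1` at 37.7%. Compound 4 `Nc1ccccc1NC(=O)/C=C/c1ccc(CSc2ccc(F)cc2)cc1` changes one group: 4-fluorophenyl in place of 3-fluorophenyl on a sulfur. For the measured compounds named here, the single measured step of this kind, a number 27.5 percentage points higher from compound 2 to compound 3 (beyond the scatter), put 3-fluorophenyl in place of 4-methoxyphenyl on a sulfur. It was seen on a different core and with a different pair of groups, so it bears only weakly here. Going by the values given here, no measured pair compares the two fluorophenyl groups directly. The expected result is therefore a number 2.3 percentage points higher from compound 1 to compound 4 (within the scatter), with no change beyond the scatter. The estimate for compound 4 is 9%, with an expected range of 1% to 22%.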

Compound 4, percent growth inhibition at one concentration: 28.8%
Beside the measured number, compound 4's estimate is 19.8 percentage points below it; measured number above the stated range.
By their numbers in this assay, from the lowest: compounds 1 and 2 (each within the scatter of the next); then compounds 4 and 3 (each within the scatter of the next).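

In this assay, the result is a number 22.1 percentage points higher from compound 1 to compound 4 (beyond the scatter) for 4-fluorophenyl in place of 3-fluorophenyl on a sulfur. The two compounds have the same atoms, joined differently, so the place of the fluorine on the ring is by itself enough to change growth inhibition on this core. Nothing available here explains this difference.

As far as these compounds go, whether moving the fluorine has the same result on the core of compound 3 remains open. So does how a 4-chlorophenyl or 4-methylphenyl group would behave on this sulfur.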